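Another aryl ether at the limit?

A few compounds are considered here, and "the series" means these few. Any claim that something is new, unique, unknown or untested is made for them only; others in the source may bear on it.

Measured so far in an ADME assay on K562/A02 cells (Homo sapiens) for cytotoxicity, read by MTT assay, with a stated time of 48 h; on this read-out higher numbers stand for weaker inhibition and lower numbers for stronger inhibition (each entry is a limit and not a number):
Compound 1 `COc1cc2c(cc1OC)CN(CCn1cc(COc3ccc([N+](=O)[O-])cc3)nn1)CC2` gives > 100000 nM
Compound 2 `COc1cc2c(cc1OC)CN(CCn1cc(COc3ccc(C)cc3)nn1)CC2` gives > 100000 nM
Compound 3 `COc1cc2c(cc1OC)CN(CCn1cc(COc3ccccc3C(C)(C)C)nn1)CC2` gives > 100000 nM

Compound 3 offers no number to start from, since its entry is only a limit. Compound 4 `COc1cc2c(cc1OC)CN(CCn1cc(COc3ccc(F)cc3)nn1)CC2` carries 4-fluorophenyl in place of 2-(tert-butyl)phenyl on an oxygen on a saturated carbon and keeps the shared core. The measured steps that bear on this change are a step that the two limits leave unreadable from compound 1 to compound 3 and a step that the two limits leave unreadable from compound 2 to compound 3 and also a step that the two limits leave unreadable from compound 1 to compound 2 with the same exchange of groups on the same oxygen or ring. No size can be carried over from them because the limit of > 100000 nM in this assay, at which 3 of the 3 values shown sit, leaves nothing to scale. Compound 1, compound 2 and compound 3 all stop at the limit despite their different aryl groups, so no direction is expected. The expected step is a number no higher from compound 3 to compound 4 (the limit leaves the size open) and it is likely to remain unreadable. Compound 4 is estimated at 100000 nM with an expected range of 50000 nM to 200000 nM and will most likely return only a limit.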

Compound 4, half-maximal inhibitory concentration: > 100000 nM
Compound 4 ended at the assay's limit; the forecaster's own chance of this, stated with the estimate: 85%; the middle value lies on the limit itself.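

No step can be read between compound 4 and compound 1, compound 2 or compound 3, because each entry is a limit and not a number: the limit of > 100000 nM in this assay, at which 4 of the 4 values shown sit.

The compounds shown leave open how these aryl groups on the oxygen compare with one another in this assay.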